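From Ring to Open Chain on Compound 2

This account rests on a few compounds, and the source may have more. Where it says the series, first, only, none or still open, it means among the compounds named here.

Three related compounds have been tested in a functional assay on HO8910 cells (Homo sapiens) for inhibition, read by MTT assay, with a stated time of 24 h, tested at 0.1 ug/mL; on this read-out higher numbers stand for more inhibition of growth at the one concentration tested and lower numbers for less inhibition of growth. There, compound 1 `O=C(CCCCC1CCSS1)Nc1ccc(Cl)cn1` is recorded as "not active" (no number reported). Compound 2 `O=C(CCCCC1CCSS1)Nc1ccc(Br)cn1` is also recorded as "not active" (no number reported), so it has no single number and shares that standing with compound 1. Compound 3 `O=C(CCCCC1CCSS1)Nc1cccc2ccccc12` gives 0.34%, the only numerical result so far.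

Compound 4 `O=C(CCCCC(S)CCS)Nc1ccc(Br)cn1` has not yet been measured. The structural change is a group of 5 heavy atoms (3 carbon, 2 sulfur; no ring) in place of a group of 5 heavy atoms (3 carbon, 2 sulfur; one five-membered non-aromatic ring with 2 hetero atoms), on a saturated chain carbon, four bonds along the chain from a carbonyl carbon: the five-membered non-aromatic ring gives way to the 1,3-disulfanylpropyl group, on a saturated chain carbon, four bonds along the chain from a carbonyl carbon.

Among the compounds with values here, no measured pair shows the effect of such a change. In this assay, the expected step is therefore no larger than the scatter, with any shift more likely towards slightly greater inhibition. Within the data shown here, the only guides are that compound 2 is "not active" (no number reported) and that compound 3 gives 0.34%. A further report without a number would not be surprising. For compound 4, the estimated value is 3%, with an expected range from 0% to 15%.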

Compound 4, percent growth inhibition at one concentration: "not active" (no number reported)
Nothing numeric was reported for compound 4, so the estimate cannot be set against anything.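

Within the data shown here, compound 2 and compound 4 are both reported as not active without a number, so no step between them can be read. No evidence bears on this result. The compounds shown leave open whether replacing the ring with the 1,3-disulfanylpropyl group changes growth inhibition.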